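Hydroxylated amide replacements on the methoxyphenyl-alkynyl benzamide core

The source may hold more compounds than are shown below. What is called first, only, known or untested is meant among the compounds shown, and "the series" means these compounds.

Compound 1 `COc1ccc(C#Cc2ccc(C(=O)N3CC4CCC(=O)C4C3)cc2)cc1` carries a bicyclic ketone amide. Among the measured compounds shown here, in a functional assay on TREX cells for negative allosteric modulation of metabotropic glutamate receptor 3 (Rattus norvegicus), read by calcium flux, with a stated time of 2.5 min (on this read-out lower numbers stand for stronger inhibition and higher numbers for weaker inhibition), compound 1 gives 2750 nM, the only number recorded for it; one further entry carries no single number. Compound 2 `COc1ccc(C#Cc2ccc(C(=O)N3CCCC(C)(O)C3)cc2)cc1` carries a hydroxylated, methylated six-membered amide ring and gives 711 nM; 1100 nM (2 entries) in this assay; its repeat entries the several entries of compound 2 in this assay, 711 nM; 1100 nM (2 entries) lie within the scatter of each other. For the measured compounds named here, no step between the measured compounds is computed, so the two values are simply reported side by side.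

Compound 3 `COc1ccc(C#Cc2ccc(C(=O)N3CC[C@H](O)C3)cc2)cc1` is not yet measured. It differs from compound 1 by a group of 6 heavy atoms (4 carbon, 1 nitrogen, 1 oxygen; one five-membered non-aromatic ring with 1 hetero atom) in place of a group of 9 heavy atoms (7 carbon, 1 nitrogen, 1 oxygen; one five-membered non-aromatic ring of carbon only, one five-membered non-aromatic ring with 1 hetero atom), on a carbonyl carbon, in words: a group of 6 heavy atoms (4 carbon, 1 nitrogen, 1 oxygen; one five-membered non-aromatic ring with 1 hetero atom) in place of a group of 9 heavy atoms (7 carbon, 1 nitrogen, 1 oxygen; one five-membered non-aromatic ring of carbon only, one five-membered non-aromatic ring with 1 hetero atom), on a carbonyl carbon. The change toward a smaller, hydroxyl-bearing amide ring is expected to move this assay a little toward stronger inhibition, on the order of a 2.1-fold lower number from compound 1 to compound 3 (0.33 log units; beyond the scatter), a step that may not exceed the scatter. Compound 3 is estimated at 1300 nM in this assay, with a range from 450 nM to 3800 nM.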

Compound 3, half-maximal inhibitory concentration: 27500 nM
For compound 3 the middle estimate is 21-fold (1.33 log units) below the measured one; measured number outside the range, above it.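

At the carbonyl carbon, in this assay, replacing the bicyclic ketone amide with 3-hydroxypyrrolidin-1-yl gives a 10-fold higher number from compound 1 to compound 3 (1.00 log units; beyond the scatter), so a smaller ring bearing a hydroxyl does not hold the inhibition at this position. Compound 3 also has a higher number than compound 2 at 711 nM; 1100 nM (2 entries), which makes it the weakest of the three numbers shown. The step is much larger than the spread of the repeat entries in this series: the several entries of compound 2 in this assay, 711 nM; 1100 nM (2 entries)

Because this one change swaps the ring system, adds a hydrogen-bond donor and removes the ketone together, the compounds shown do not tell which of these accounts for the loss. Also open, going by these compounds, are the other enantiomer of compound 3 and whether an unsubstituted pyrrolidine or a 3-methoxypyrrolidine would recover inhibition.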